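Ring methylation and growth inhibition in the series

The source may hold more compounds than are shown below. What is called first, only, known or untested is meant among the compounds shown, and "the series" means these compounds.

Compound 1 `NC(=O)c1cc(I)ccc1NC(=O)COc1ccccc1` gives 73% in a functional assay on K562 cells (Homo sapiens) for inhibition, read by trypan blue exclusion, with a stated time of 24 h, tested at 10 uM; a higher number here means more inhibition of growth at the concentration tested, a lower number less inhibition of growth. Compound 2 `Cc1ccc(OCC(=O)Nc2ccc(I)cc2C(N)=O)cc1` gives 49.8% in this assay; the change is methyl in place of hydrogen on an aromatic carbon, and the step is a number 23.2 percentage points lower from compound 1 to compound 2 (beyond the scatter). Compound 3 `Cc1ccc(NC(=O)COc2ccccc2)c(C(N)=O)c1` gives 72% in this assay; its core differs from the core of compound 1 by methyl in place of iodo on an aromatic carbon, and the step of a number 1 percentage points lower from compound 1 to compound 3 (within the scatter) stays small. Compound 4 `Cc1ccc(NC(=O)COc2ccccc2C)c(C(N)=O)c1` is not yet measured. Within the data shown here, it differs from compound 3 by methyl in place of hydrogen on an aromatic carbon, the same kind of change as the one seen between compound 1 and compound 2, though here the methyl sits ortho to a large group, whereas before it sat para to a large group. Among the measured compounds shown here, the expected step is a number 20 percentage points lower from compound 3 to compound 4 (beyond the scatter), a drop of similar size because the only precedent is a number 23.2 percentage points lower from compound 1 to compound 2 (beyond the scatter), widened for the different place. Compound 4 is estimated in this assay at 52%, within 30% to 72%.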

Compound 4, percent growth inhibition at one concentration: 45.6%
Compound 4: middle estimate off by 6.4 percentage points, on the high side; measured number inside the range.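

In this assay the change from phenyl to 2-methylphenyl gives a number 26.4 percentage points lower from compound 3 to compound 4 (beyond the scatter) and lowers growth inhibition on this core as well. Two pairs are a narrow base, and the methyl does not stand in the same place in both, being ortho to a large group only in compound 4, so the result does not separate place from core and gives no cause for the drop. Even so, the size of the change carries over between the two cores: the same change on two cores in this assay, a number 23.2 percentage points lower (beyond the scatter) from compound 1 to compound 2 and a number 26.4 percentage points lower (beyond the scatter) from compound 3 to compound 4, 3.2 percentage points apart, within the scatter of two such steps

Still open, going by these compounds, is whether a larger group at the same carbon, such as ethyl or methoxy, follows the methyl. Also open, on these data alone, is whether an amine or a carboxylic acid there would give a similar step.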